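The compounds below may be only part of what the source reports. "The series", "measured", "known", "first", "only" and "open" are said of these compounds alone.

Measured so far in an assay on cells for antagonist activity at transient receptor potential cation channel subfamily V member 1 (Homo sapiens), read by FLIPR and calcium flux, with a stated time of 6 min; on this read-out lower numbers stand for stronger inhibition and higher numbers for weaker inhibition:
- compound 1, `CCOCCOc1nc(C(C)(C)C)ccc1CNC(=O)C(C)c1ccc(NS(C)(=O)=O)c(F)c1`: 23.9 nM
- compound 2, `CC(C(=O)NCc1ccc(C(C)(C)C)nc1OCc1ccc(F)cc1)c1ccc(NS(C)(=O)=O)c(F)c1`: 0.8 nM
- compound 3, `CCCCSc1nc(C(C)(C)C)ccc1CNC(=O)C(C)c1ccc(NS(C)(=O)=O)c(F)c1`: 3.2 nM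

Compound 3 holds the second highest of these three numbers. Its nearest neighbour is compound 2: a 4.0-fold higher number from compound 2 to compound 3 (0.60 log units; beyond the scatter). Its furthest is compound 1: a 7.5-fold lower number from compound 1 to compound 3 (0.87 log units; beyond the scatter).

Compound 4, `CC(C(=O)NCc1ccc(C(C)(C)C)nc1SC1CCCC1)c1ccc(NS(C)(=O)=O)c(F)c1`, differs from compound 3 in one place: cyclopentyl in place of butyl on a sulfur. Both measured steps that bear on this site changed the whole substituent on the aromatic carbon, so neither matches a swap of butyl for cyclopentyl on a sulfur. In this assay compound 4 is therefore expected to land close to compound 3, with a step of about a 1.3-fold lower number from compound 3 to compound 4 (0.11 log units; within the scatter) that may stay within the scatter. The estimate for compound 4 is 2.5 nM, ranging from 0.8 nM to 8 nM.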

Compound 4, inhibition constant: 2.5 nM
Beside the measured number, compound 4's estimate shows no gap at the digits printed, and the stated range covers the measured number.
By their numbers in this assay, from the lowest: compound 2; then compounds 4 and 3 (each within the scatter of the next); then compound 1.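

Swapping butyl for cyclopentyl on the sulfur does not separate the two compounds in this assay: a 1.3-fold lower number from compound 3 to compound 4 (0.11 log units; within the scatter), so at this position a ring of carbon serves as well as an open chain. Cyclopentylsulfanyl still stands apart from the two oxygen-linked groups, with a 3.1-fold higher number from compound 2 to compound 4 (0.49 log units; beyond the scatter) for (4-fluorobenzyl)oxy and a 9.6-fold lower number from compound 1 to compound 4 (0.98 log units; beyond the scatter) for 2-ethoxyethoxy. No measurement shown gives a reason for these steps. Open still is how a cyclohexyl or a phenyl on the sulfur would read, and how cyclopentyl on an oxygen would compare.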